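The source may hold more compounds than are shown below. What is called first, only, known or untested is meant among the compounds shown, and "the series" means these compounds.

Three compounds have been tested in a functional assay on MCF7 cells (Homo sapiens) for cytotoxicity, read by MTT assay, with a stated time of 72 h; on this read-out lower numbers stand for stronger inhibition and higher numbers for weaker inhibition:

compound 1 `Clc1ccccc1-c1nnc2nnc(N3CCCC3)nn12` gives 29600 nM
compound 2 `CC(C)c1nnc2nnc(N3CCCC3)nn12` gives 46800 nM
compound 3 `CC(C)(C)c1nnc2nnc(N3CCCC3)nn12` gives 55000 nM

Compound 3 carries the highest number of the three, but its step to compound 2 is small, a 1.2-fold higher number from compound 2 to compound 3 (0.07 log units; within the scatter), and its step to compound 1, a 1.9-fold higher number from compound 1 to compound 3 (0.27 log units; within the scatter), is also within the scatter, so the three compounds cannot be told apart on these numbers.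

Compound 4 `CCc1nnc2nnc(N3CCCC3)nn12` differs from compound 3 at one place: ethyl in place of tert-butyl on an aromatic carbon. Within the data shown here, the one measured step that bears on this change is the step from compound 2 to compound 3, in which the same saturated carbon gained a methyl, a 1.2-fold higher number from compound 2 to compound 3 (0.07 log units; within the scatter). Shortening the chain again, from tert-butyl to ethyl, is therefore expected to leave the number about where compound 3 sits, with no step beyond the scatter in either direction. For compound 4 the step from compound 3 is estimated as a 1.1-fold lower number from compound 3 to compound 4 (0.04 log units; within the scatter). Compound 4 is thus expected to give about 50000 nM in this assay, with a likely range from 20000 nM to 120000 nM.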

Compound 4, half-maximal inhibitory concentration: 47000 nM
Estimate against measurement, compound 4: 1.1-fold (0.03 log units) above; the measured number falls inside the stated range.
By their numbers in this assay, from the lowest: compounds 1, 2, 4 and 3 (each within the scatter of the next).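

With ethyl, this aromatic carbon has now carried four different groups, and in this assay none of them can be told apart: the change from tert-butyl (a 1.2-fold lower number from compound 3 to compound 4 (0.07 log units; within the scatter)), the change from isopropyl (a 1.0-fold higher number from compound 2 to compound 4 (0.00 log units; within the scatter)) and the change from 2-chlorophenyl (a 1.6-fold higher number from compound 1 to compound 4 (0.20 log units; within the scatter)) all stay within the scatter. At this position, then, ethyl with 2 heavy atoms reads the same as tert-butyl with 4, and the same as a group carrying a ring. Nothing available explains why these numbers sit so close together.

As far as these compounds go, it remains open whether any group on this carbon can shift the number beyond the scatter, such as an amine, a carboxylic acid or a longer chain. The four compounds also share the rest of their structure, so they cannot show how a change elsewhere on the core would read.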